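From 4-methoxyphenyl to 3-nitrophenyl on the shared core

The compounds below may be only part of what the source reports. "The series", "measured", "known", "first", "only" and "open" are said of these compounds alone.

In a functional assay on UACC-62 cells (Homo sapiens) for cytotoxicity, read by sulforhodamine B assay (a lower number here means a stronger inhibitor of growth, a higher number a weaker inhibitor of growth), compound 1 (`CC1=CC[C@@H]([C@@](C)(O)CCCC(C)(C)NC(=S)NN)CC1`) gives 18500 nM, compound 2 (`CC1=CC[C@@H]([C@@](C)(O)CCCC(C)(C)NC(=S)N/N=C\c2ccccc2)CC1`) gives 12700 nM, and compound 3 (`COc1ccc(/C=N\NC(=S)NC(C)(C)CCC[C@](C)(O)[C@@H]2CC=C(C)CC2)cc1`) gives 7420 nM. Compound 3 therefore stands clear of compound 1, with a 2.5-fold lower number from compound 1 to compound 3 (0.40 log units; beyond the scatter), but level with compound 2, with a 1.7-fold lower number from compound 2 to compound 3 (0.23 log units; within the scatter). The first aromatic group brought only a 1.5-fold lower number from compound 1 to compound 2 (0.16 log units; within the scatter). Compound 4 (`CC1=CC[C@@H]([C@@](C)(O)CCCC(C)(C)NC(=S)N/N=C\c2cccc([N+](=O)[O-])c2)CC1`) carries 3-nitrophenyl in place of 4-methoxyphenyl on a carbon with a double bond to nitrogen. Among the measured compounds shown here, no measured step tests a nitro group. For the measured compounds named here, the one change on the aromatic ring, a 1.7-fold lower number from compound 2 to compound 3 (0.23 log units; within the scatter), is small, so no step beyond the scatter is expected. The estimated step is a 1.2-fold higher number from compound 3 to compound 4 (0.08 log units; within the scatter). For compound 4 the expected value is 9000 nM, within an estimated range of 4500 nM to 18000 nM.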

Compound 4, concentration for 50% growth inhibition: 7840 nM
Compound 4: the middle estimate sits 1.1-fold (0.06 log units) above what was measured; measured number inside the range.
By their numbers in this assay, from the lowest: compounds 3, 4, 2 and 1 (each within the scatter of the next, the first and the last beyond it).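

In this assay, 3-nitrophenyl in place of 4-methoxyphenyl on a carbon with a double bond to nitrogen gives a 1.1-fold higher number from compound 3 to compound 4 (0.02 log units; within the scatter) and so leaves the two compounds level. Nitro in place of hydrogen on an aromatic carbon gives a 1.6-fold lower number from compound 2 to compound 4 (0.21 log units; within the scatter) and so also stays level, which means neither methoxy nor nitro on the ring now gives a step beyond the scatter from compound 2. Nothing measured here bears on why these numbers stay level.

From the compounds shown here alone, it remains open whether 4-nitrophenyl or 3-methoxyphenyl would give similar numbers. Going by these compounds, it also remains open whether an amine or a carboxylic acid on the ring would move the number beyond the scatter.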